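A few compounds are considered here, and "the series" means these few. Any claim that something is new, unique, unknown or untested is made for them only; others in the source may bear on it.

Compound 1, `CC(CCC(=O)O)Cc1cccc(OCc2ccc3ccccc3n2)c1`, gives 140 nM.
Compound 2, `c1cc(OCCCc2nnn[nH]2)cc(OCc2ccc3ccccc3n2)c1`, gives 42 nM.

In an assay on membranes from lung (Cavia porcellus) for binding affinity to cysteinyl leukotriene receptor (Homo sapiens) (on this read-out lower numbers stand for stronger inhibition and higher numbers for weaker inhibition), compound 1 gives 140 nM, the higher of the two numbers. Compound 2 gives 42 nM, and the step of a 3.3-fold lower number from compound 1 to compound 2 (0.52 log units; beyond the scatter) lies beyond the scatter. Compound 3, `CCCC(CCC(=O)O)Cc1cccc(OCc2ccc3ccccc3n2)c1`, differs from compound 1 by ethyl in place of hydrogen on a saturated chain carbon, three bonds along the chain from an aromatic carbon. Among the measured compounds shown here, no measured step bears on this change: the step from compound 1 to compound 2 alters a different part of the molecule, so nothing here speaks for a shift in either direction. Compound 3 is therefore expected to show no step beyond the scatter, no change at the digits printed from compound 1 to compound 3 (within the scatter). The estimate for compound 3 is 140 nM, between 50 nM and 400 nM.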

Compound 3, inhibition constant: 50 nM
For compound 3 the middle estimate is 2.8-fold (0.45 log units) above the measured one, and the stated range covers the measured number.
By their numbers in this assay, from the lowest: compounds 2 and 3 (each within the scatter of the next); then compound 1.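

In this assay the result is a 2.8-fold lower number from compound 1 to compound 3 (0.45 log units; beyond the scatter) with ethyl in place of hydrogen on a saturated chain carbon, three bonds along the chain from an aromatic carbon. The earlier step replaced the whole 4-carboxy-2-methylbutyl chain, whereas this one shows that lengthening methyl to propyl at this one carbon is enough to move the number beyond the scatter. No measured evidence here accounts for the shift. From the compounds shown here alone, whether a butyl or a phenyl group on this carbon would lower the number further remains open. So does the effect of a hydroxyl group there.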